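Cytotoxicity notes: ortho substituent on the anilide ring

The compounds below may be only part of what the source reports. "The series", "measured", "known", "first", "only" and "open" are said of these compounds alone.

Compounds measured so far, with the read-out of an ADME assay on MT4 cells (Homo sapiens) for cytotoxicity, read by MTT assay, with a stated time of 5 days; on this read-out lower numbers stand for higher toxicity in this test and higher numbers for lower toxicity in this test:
- compound 1, `O=C(CSc1snnc1-c1ccc(Br)cc1Br)Nc1ccccn1`: 42400 nM
- compound 2, `O=C(CSc1snnc1-c1ccc(Br)cc1Br)Nc1ccccc1F`: >= 27800 nM
- compound 3, `O=C(CSc1snnc1-c1ccc(Br)cc1Br)Nc1ccccc1Cl`: > 240000 nM

Compound 3 carries the 2-chlorophenyl group on the amide nitrogen. Its value in this assay is a limit, not a number, as the limit of > 240000 nM in this assay, at which 1 of the 3 values shown sits, records; of the three values shown, it is one of two that are limits. The value of compound 2 is likewise a limit, recorded as the limit of >= 27800 nM in this assay, at which 1 of the 3 values shown sits. Only compound 1 gives a plain number.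

The step of an at least 5.6-fold higher number from compound 1 to compound 3 (0.75 log units; beyond the scatter) is beyond the scatter and can be read. The step that the limit leaves unreadable from compound 1 to compound 2 cannot be read, nor can a step that the two limits leave unreadable from compound 2 to compound 3. Both of these steps involve a limit.

Compound 4, `Cc1ccccc1NC(=O)CSc1snnc1-c1ccc(Br)cc1Br`, differs from compound 3 by methyl in place of chloro on an aromatic carbon. Among the measured compounds shown here, no measured step changes chloro to methyl, so the expectation rests on the general picture: two of three compounds sit at limits and the one numbered value of compound 1 is already high. The step of an at least 1.6-fold lower number from compound 3 to compound 4 (0.20 log units; that floor lies within the scatter) is therefore expected to stay within the scatter or be unreadable. For compound 4 the estimated value in this assay is 150000 nM, in the range 40000 nM to 400000 nM.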

Compound 4, half-maximal cytotoxic concentration: 202000 nM
The estimate for compound 4 lay 1.3-fold (0.13 log units) below the measured number, within the range that was stated.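

In this assay, among the compounds shown here, the 2-methylphenyl group gives the first plain number for a substituted phenyl on the amide nitrogen, and its step against pyridin-2-yl can be read in full: a 4.8-fold higher number from compound 1 to compound 4 (0.68 log units; beyond the scatter). Methyl in place of chloro, ortho to a large group, gives an at least 1.1-fold lower number from compound 3 to compound 4 (0.07 log units; that floor lies within the scatter); the floor of this step lies within the scatter, so no drop from chloro to methyl is shown, and its true size remains unknown. Compound 3 is recorded only as a limit, and the higher number seen against pyridin-2-yl therefore now rests on a measured value as well as on that limit: the limit of > 240000 nM in this assay, at which 1 of the 4 values shown sits.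

On these data alone, the steps from compound 1, compound 3 and compound 4 involving compound 2 cannot be read, and the place of the 2-fluorophenyl group stays open, as compound 2 is also recorded only as a limit: the limit of >= 27800 nM in this assay, at which 1 of the 4 values shown sits. Also open is how a methoxy group, an amine or a longer chain such as ethyl at this same place would read in this assay, since chloro and methyl alone do not define a trend.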